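Replacing naphthalen-2-yl with 3-phenoxypropyl on a carbonyl carbon

The compounds below may be only part of what the source reports. "The series", "measured", "known", "first", "only" and "open" are said of these compounds alone.

Compound 1 `O=C(NO)c1cnc(N2C[C@@H]3CN(S(=O)(=O)c4ccc5ccccc5c4)C[C@@H]3C2)nc1`: 1130 nM
Compound 2 `O=C(NO)c1cnc(N2C[C@H]3CN(C(=O)c4ccc5ccccc5c4)C[C@H]3C2)nc1`: 210 nM

Both values come from a functional assay on HeLa cells (Homo sapiens) for inhibition, read by sulforhodamine B assay, with a stated time of 72 h; on this read-out lower numbers stand for stronger inhibition of growth and higher numbers for weaker inhibition of growth. Compound 2 at 210 nM has the lower number of the two, and its gap to compound 1 at 1130 nM lies beyond the usual scatter. So compound 2 is the better measured starting point for the next comparison.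

Compound 3 `O=C(NO)c1cnc(N2C[C@H]3CN(C(=O)CCCOc4ccccc4)C[C@H]3C2)nc1` has not yet been measured. It carries 3-phenoxypropyl in place of naphthalen-2-yl on a carbonyl carbon. For the measured compounds named here, no measured pair shows what such a swap does, so any expectation here is rough. The expected 1.5-fold higher number from compound 2 to compound 3 (0.18 log units; within the scatter) is a modest rise in the number, towards weaker inhibition of growth, and it may not clear the scatter. Compound 3 is estimated at 320 nM, with an expected range of 110 nM to 900 nM.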

Compound 3, concentration for 50% growth inhibition: 3950 nM
For compound 3 the middle estimate is 12-fold (1.09 log units) below the measured one; measured number outside the range, above it.
By their numbers in this assay, from the lowest: compound 2; then compound 1; then compound 3.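

In this assay, the position on the carbonyl carbon does not treat groups of equal size alike: naphthalen-2-yl and 3-phenoxypropyl have the same count of heavy atoms, yet the swap gives a 19-fold higher number from compound 2 to compound 3 (1.27 log units; beyond the scatter). Size measured as heavy atoms therefore does not by itself set growth inhibition at this position. The swap also replaces two six-membered aromatic rings with one and brings in an oxygen as a hydrogen-bond acceptor, and this single step cannot separate those changes, while no measurement at hand gives a reason for the loss.

A 3-phenylpropyl chain, which lacks the oxygen, would test that atom apart from the ring count. A plain phenyl group or a quinoline ring on the same carbonyl carbon would show how much the number depends on the ring system itself.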